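The source may hold more compounds than are shown below. What is called first, only, known or untested is meant among the compounds shown, and "the series" means these compounds.

The measured compounds:

Compound 1, `Cc1nc(S(C)(=O)=O)ccc1Oc1ncnc(OC2CCN(C(=O)O[C@H](C)C(F)(F)F)CC2)c1F`, gives 85% in a functional assay on isolated protein for inhibition of Glucose-dependent insulinotropic receptor (Rattus norvegicus), read by HTRF and cAMP accumulation; a higher number here means a larger maximal response, a lower number a smaller maximal response.
Compound 2, `Cc1nc(S(C)(=O)=O)ccc1Oc1ncnc(OC2CCN(C(=O)SC(C)C)CC2)c1F`, gives 81%.
Compound 3, `Cc1nc(S(C)(=O)=O)ccc1Oc1ncnc(OC2CCN(C(=O)c3nc(C(C)(C)F)no3)CC2)c1F`, gives 84%.

Compound 3 stands as the second highest of these three numbers, though the steps to both of its neighbours lie within the scatter: a number 1 percentage points lower from compound 1 to compound 3 (within the scatter) and a number 3 percentage points higher from compound 2 to compound 3 (within the scatter). All three compounds share the same core and differ only in the group carried on a carbonyl carbon attached to the ring nitrogen.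

Compound 4, `CCc1cnc(C(=O)N2CCC(Oc3ncnc(Oc4ccc(S(C)(=O)=O)nc4C)c3F)CC2)nc1`, is not yet measured. It differs from compound 3 at that same carbonyl carbon: a group of 8 heavy atoms (6 carbon, 2 nitrogen; one six-membered aromatic ring with 2 hetero atoms) in place of a group of 9 heavy atoms (5 carbon, 2 nitrogen, 1 oxygen, 1 fluorine; one five-membered aromatic ring with 3 hetero atoms), on a carbonyl carbon.

The three measured steps bear on this change, since each also exchanges the group on that carbonyl carbon: a number 4 percentage points lower from compound 1 to compound 2 (within the scatter), a number 1 percentage points lower from compound 1 to compound 3 (within the scatter) and a number 3 percentage points higher from compound 2 to compound 3 (within the scatter). None of them moved the largest response beyond the scatter, whether the group was a chain or a five-membered aromatic ring. On that basis, no step beyond the scatter is expected in this assay for compound 4. The expected step is a number 1 percentage points lower from compound 3 to compound 4 (within the scatter). Compound 4 is therefore estimated at 83%, with a range from 72% to 94%.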

Compound 4, largest response reached (reported as efficacy), in percent of the reference or control that the assay uses: 80%
For compound 4 the middle estimate is 3 percentage points above the measured one, within the range that was stated.
By their numbers in this assay, from the lowest: compounds 4, 2, 3 and 1 (each within the scatter of the next).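

In this assay, among the compounds shown here, the 5-ethylpyrimidin-2-yl group brings a six-membered aromatic ring onto the carbonyl carbon, a kind of group the earlier compounds did not carry there, and the result stays close to all three of them: a number 4 percentage points lower from compound 3 to compound 4 (within the scatter) and a number 1 percentage points lower from compound 2 to compound 4 (within the scatter) and also a number 5 percentage points lower from compound 1 to compound 4 (within the scatter) in the same read-out. At this position the two open-chain groups, the five-membered aromatic ring and now a six-membered aromatic ring therefore give largest responses that cannot be told apart, which extends the earlier picture from a five-membered ring to a second ring type. No measurement shown here bears on why the numbers stay together.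

The compounds shown leave open whether a group of another kind on this carbonyl carbon, such as an amine or a carboxylic acid, would move the largest response beyond the scatter. They also leave open what a longer chain in place of the ethyl on the pyrimidine would do, and, since only the largest response is given, whether these groups differ in any other respect.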